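Swapping the Benzyl Ester Side Chain for Sec-Butyl

The source may hold more compounds than are shown below. What is called first, only, known or untested is meant among the compounds shown, and "the series" means these compounds.

Of the compounds shown here, three sharing one core have been measured in a functional assay on the whole organism (Tail, strain ICR) with Mus musculus as the target, in the tail flick test, with a stated time of 90 min, at a dose of 25 umol/kg by the oral route; on this read-out higher numbers stand for a stronger effect at the one dose given and lower numbers for a weaker effect. Compound 1 `CSCC[C@H](NC(=O)CN(c1nc(Cl)nc2[nH]cnc12)C1CC1)C(=O)OCc1ccccc1` gives 44.6%. Compound 3 `C[C@H](NC(=O)CN(c1nc(Cl)nc2[nH]cnc12)C1CC1)C(=O)O` gives 43.5%. Compound 2 `O=C(CN(c1nc(Cl)nc2[nH]cnc12)C1CC1)N[C@@H](CC(=O)OCc1ccccc1)C(=O)OCc1ccccc1` gives 15.6%, the lowest of the three numbers; compound 3 stands nearest to it and compound 1 furthest, both gaps beyond the scatter. One measured step leads into compound 2: a number 29 percentage points lower from compound 1 to compound 2 (beyond the scatter), a loss beyond the scatter.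

Compound 4 `CC[C@H](C)[C@H](NC(=O)CN(c1nc(Cl)nc2[nH]cnc12)C1CC1)C(=O)OCc1ccccc1` differs from compound 2 in one place: sec-butyl in place of (benzyloxycarbonyl)methyl on a saturated chain carbon bound to an amide-type nitrogen and a carbonyl carbon. The (benzyloxycarbonyl)methyl group that leaves is the very piece whose arrival produced the drop seen in the step from compound 1 to compound 2, and a sec-butyl group of similar size to the side chains of compound 1 and compound 3 takes its place. The expected step is therefore a recovery, close in size to that earlier loss, as a number 24.4 percentage points higher from compound 2 to compound 4 (beyond the scatter) expresses. Compound 4 is estimated at 40%, with a likely range from 24% to 56%.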

Compound 4, a percentage reported as activity, at one dose (the size of the read-out at that dose, not a potency): 36.3%
For compound 4 the middle estimate is 3.7 percentage points above the measured one, and the stated range covers the measured number.
By their numbers in this assay, from the lowest: compound 2; then compounds 4, 3 and 1 (each within the scatter of the next).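

At the saturated chain carbon bound to an amide-type nitrogen and a carbonyl carbon, sec-butyl in place of (benzyloxycarbonyl)methyl gives a number 20.7 percentage points higher from compound 2 to compound 4 (beyond the scatter) in this assay, so the low number of compound 2 goes with that one side chain and not with the shared core. Sec-butyl in place of 2-(methylsulfanyl)ethyl gives a number 8.3 percentage points lower from compound 1 to compound 4 (within the scatter), so these two ring-free side chains cannot be told apart on this read-out. Nothing at hand explains why the (benzyloxycarbonyl)methyl group goes with the lower number.

Going by these compounds, it remains open whether the drop follows the aromatic ring or the ester within that group: a benzyl group or a carboxylic acid on this carbon would help separate the two. An amine or a longer carbon chain at the same place would show how widely the side chain can vary.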